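Imidazole for imidazoline on two aryl cores

This account rests on a few compounds, and the source may have more. Where it says the series, first, only, none or still open, it means among the compounds named here.

Compound 1 `c1ccc(-c2cnco2)c(NCC2=NCCN2)c1`: in a functional assay for activation of Alpha-1D adrenergic receptor (Homo sapiens) (a lower number here means that less compound is needed, a higher number that more compound is needed for the effect), compound 1 gives < 5020 nM, which is a limit.
Compound 2 `c1ccc(-c2cnco2)c(NCc2c[nH]cn2)c1`: compound 2 gives < 252 nM, also a limit.
Compound 3 `CCN(CC)C(=O)c1ccccc1OCC1=NCCN1`: compound 3 gives < 100000 nM, again a limit.

From compound 1 to compound 2 the change is a group of 5 heavy atoms (3 carbon, 2 nitrogen; one five-membered aromatic ring with 2 hetero atoms) in place of a group of 5 heavy atoms (3 carbon, 2 nitrogen; one five-membered non-aromatic ring with 2 hetero atoms), on a saturated chain carbon bound to a nitrogen on an aromatic ring, and the step is a step that the two limits leave unreadable from compound 1 to compound 2. Within the data shown here, all three numbers are limits (the limit of < 100000 nM in this assay, at which 1 of the 3 values shown sits, (the limit of < 252 nM in this assay, at which 1 of the 3 values shown sits), (the limit of < 5020 nM in this assay, at which 1 of the 3 values shown sits)), so no measured step can be sized. Compound 4 `CCN(CC)C(=O)c1ccccc1OCc1c[nH]cn1` carries the same kind of change on the core of compound 3: a group of 5 heavy atoms (3 carbon, 2 nitrogen; one five-membered aromatic ring with 2 hetero atoms) in place of a group of 5 heavy atoms (3 carbon, 2 nitrogen; one five-membered non-aromatic ring with 2 hetero atoms), on a saturated chain carbon bound to an oxygen on an aromatic ring, the chain carbon here being bound to an oxygen on an aromatic ring rather than to a nitrogen on an aromatic ring. The difference between the two cores is not broken down here. For compound 4 a value of about 10000 nM is expected, between 500 nM and 100000 nM, a step that the limit leaves unreadable from compound 3 to compound 4. That expectation rests on the limit of compound 3, < 100000 nM, and on the unreadable step that the two limits leave unreadable from compound 1 to compound 2.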

Compound 4, half-maximal effective concentration: < 100000 nM
Compound 4: a limit, no number; the forecaster's own chance of this, stated with the estimate: 60%; the middle value is on the limit's open side.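

In this assay compound 4 gives < 100000 nM, which is a limit. Compound 3 also gives only a limit, so no step can be read between compound 3 and compound 4. The compounds shown leave open whether imidazole for imidazoline changes the effect on either core.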